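The source may hold more compounds than are shown below. What is called first, only, known or untested is meant among the compounds shown, and "the series" means these compounds.

Compound 1 `O=C(Nc1cccc(-n2cc(-c3ccncc3)c(-c3ccc(Cl)c(O)c3)n2)c1)Nc1ccc(Cl)c(Cl)c1` is the reference of this account. In a functional assay on LOX IMVI cells (Homo sapiens) for inhibition, read by sulforhodamine B assay, with a stated time of 48 h (on this read-out lower numbers stand for stronger inhibition of growth and higher numbers for weaker inhibition of growth), compound 1 gives 3570 nM, the lowest of the two numbers shown. Compound 3 `COc1cc(-c2nn(-c3cccc(NC(=O)Nc4ccc(Cl)c(C(F)(F)F)c4)c3)cc2-c2ccncc2)ccc1Cl` gives 4610 nM, a gap from compound 1 that lies within the scatter. Compound 2 `COc1cc(-c2nn(-c3cccc(NC(=O)c4ccc(Cl)c(C(F)(F)F)c4)c3)cc2-c2ccncc2)ccc1Cl` reaches only a limit of the assay, > 32500 nM, as noted in the limit of > 32500 nM in this assay, at which 1 of the 3 values shown sits. Among the measured compounds shown here, the one measured step, an at least 7.0-fold lower number from compound 2 to compound 3 (0.84 log units; beyond the scatter), concerns the link to the outer ring, not the ring itself. Compound 4 `O=C(Nc1cccc(-n2cc(-c3ccncc3)c(-c3ccc(Cl)c(O)c3)n2)c1)Nc1cccc(C(F)(F)F)c1` differs from compound 1 only there: 3-(trifluoromethyl)phenyl in place of 3,4-dichlorophenyl on an amide-type nitrogen. For the measured compounds named here, no measured step bears on such a change, so compound 4 is expected to stay near compound 1, with a 1.1-fold higher number from compound 1 to compound 4 (0.05 log units; within the scatter) within the scatter. Compound 4 is thus estimated at 4000 nM, between 1500 nM and 12000 nM.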

Compound 4, concentration for total growth inhibition: 9580 nM
For compound 4 the middle estimate is 2.4-fold (0.38 log units) below the measured one, within the range that was stated.
By their numbers in this assay, from the lowest: compounds 1 and 3 (each within the scatter of the next); then compound 4. At a limit, above all of these: compound 2.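

Among the compounds shown here, the replacement of 3,4-dichlorophenyl by 3-(trifluoromethyl)phenyl on the amide-type nitrogen gives, in this assay, a 2.7-fold higher number from compound 1 to compound 4 (0.43 log units; beyond the scatter), the first measured step that concerns the outer ring itself rather than its link. This position is therefore not indifferent to what the ring carries, although the step is modest. Nothing shown gives a cause for this step.

The compounds shown leave open how this ring would fare carrying a nitrile, a single fluorine or a dimethylamino group, and whether an unsubstituted phenyl would stay near compound 1.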